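A few compounds are considered here, and "the series" means these few. Any claim that something is new, unique, unknown or untested is made for them only; others in the source may bear on it.

Measured compounds, in an in vitro assay on BTI-TN-5B1-4 cells for inhibition of Amine oxidase [flavin-containing] B (Homo sapiens); a lower number here means a stronger inhibitor, a higher number a weaker inhibitor:
compound 1, `Cc1ccc(C2CC(=O)c3ccc(F)cc3O2)cc1`, gives 160 nM;
compound 2, `Cc1ccc2c(c1)OC(c1ccccc1)CC2=O`, gives 3620 nM;
compound 3, `Cc1ccc(C2CC(=O)c3ccccc3O2)cc1`, gives 2070 nM.

Compound 2 has the highest of the three numbers, yet its gap to compound 3 lies within the scatter, so no order between those two can be read. Compound 2 and compound 3 are built from the same atoms joined differently; the difference between the two cores is not broken down here. Among the measured compounds shown here, the one counted step is fluoro in place of hydrogen on an aromatic carbon, which gave a 13-fold lower number from compound 3 to compound 1 (1.11 log units; beyond the scatter).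

Compound 4, `Cc1ccc2c(c1)OC(c1ccc(F)cc1)CC2=O`, is not yet measured. It arises from compound 2 by fluoro in place of hydrogen on an aromatic carbon. This is the same kind of change as that from compound 3 to compound 1, but not the same: there the fluoro entered on a ring that is part of a fused system of two rings, meta and para to the fused ring, whereas here it enters on a six-membered ring of carbon only, para to a large group. Because the step of a 13-fold lower number from compound 3 to compound 1 (1.11 log units; beyond the scatter) was measured at a different place, it is taken only as a loose guide. Compound 4 is expected to give a step of a 2.4-fold lower number from compound 2 to compound 4 (0.38 log units; beyond the scatter) in this assay. Compound 4 is estimated at 1500 nM, with a likely range from 500 nM to 4500 nM.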

Compound 4, half-maximal inhibitory concentration: 130 nM
Compound 4: middle estimate off by 12-fold (1.06 log units), on the high side; the measured number lies below the stated range.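

In this assay, fluoro in place of hydrogen on an aromatic carbon gave a 28-fold lower number from compound 2 to compound 4 (1.44 log units; beyond the scatter) and so repeated on a second core what had been seen on the first: the same change on two cores in this assay, a 13-fold lower number (1.11 log units; beyond the scatter) from compound 3 to compound 1 and a 28-fold lower number (1.44 log units; beyond the scatter) from compound 2 to compound 4, 2.2-fold (0.33 log units) apart, within the scatter of two such steps. In these two pairs, then, the change lowered the number by a large step on both cores, even though the fluoro entered on the fused system of two rings in compound 1 and on the six-membered ring of carbon only, para to a large group, in compound 4. This shows that the step carried over between these two cores, but two pairs do not show that it would hold on any other core, and they do not explain why it occurs.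

The compounds shown leave open what a fluoro on both of these rings in one molecule would give. They also leave open whether chloro, methoxy or an amine in place of the fluoro would give a step of similar size.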